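Swapping 2,2,2-trifluoroethoxy for propylsulfanyl on a shared core

The source may report more compounds than this note shows. Statements on the series, on what has been measured and on what is new or still open speak of the compounds shown alone.

- Compound 1 `CNc1nc(N)nc2c1ncn2/C=C1/CC1(CO)CO`: 265000 nM
- Compound 2 `Nc1nc(OCC(F)(F)F)c2ncn(/C=C3/CC3(CO)CO)c2n1`: > 300000 nM (a limit)
- Compound 3 `Nc1nc(OCc2ccccc2)c2ncn(/C=C3/CC3(CO)CO)c2n1`: > 300000 nM (a limit)

These values come from an ADME assay on HFF cells (Homo sapiens) for cytotoxicity, with a stated time of 8 days; a higher number here means that more compound is tolerated, a lower number that less compound is tolerated. Compound 2 has only a limit, not a number, and stands at the limit of > 300000 nM in this assay, at which 2 of the 3 values shown sit.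

Compound 4 `CCCSc1nc(N)nc2c1ncn2/C=C1/CC1(CO)CO` keeps the shared core and changes one group: propylsulfanyl in place of 2,2,2-trifluoroethoxy on an aromatic carbon.

The closest measured swaps sit on that same aromatic carbon: an at least 1.1-fold higher number from compound 1 to compound 2 (0.05 log units; that floor lies within the scatter), and an at least 1.1-fold higher number from compound 1 to compound 3 (0.05 log units; that floor lies within the scatter). Neither shows a change beyond the scatter, though neither brings in propylsulfanyl. A change beyond the scatter is therefore not expected, in either direction. The expected step is an at least 1.3-fold lower number from compound 2 to compound 4 (0.13 log units; that floor lies within the scatter). Compound 4 is estimated at 220000 nM, with an expected range from 80000 nM to 300000 nM.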

Compound 4, half-maximal cytotoxic concentration: > 300000 nM
Compound 4 ended at the assay's limit; the forecaster's own chance of this, stated with the estimate: 45%; middle value at least 1.3-fold (0.13 log units) from the limit.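

In this assay, compound 4 also gives only a limit, so a sulfur-linked chain on this aromatic carbon joins the oxygen-linked groups there. Among the compounds shown here, the one readable step is an at least 1.1-fold higher number from compound 1 to compound 4 (0.05 log units; that floor lies within the scatter), and the steps among compound 2, compound 3 and compound 4 cannot be read. Three different groups at this place therefore end at the same limit: the limit of > 300000 nM in this assay, at which 3 of the 4 values shown sit.

Going by these compounds, how far past that limit these compounds lie stays open, so they cannot be ranked against one another. Also open, on these data alone, is whether a carboxylic acid or a longer chain on this carbon would give a measurable number.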